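Swapping the Aryl Group on the Amine Nitrogen

The compounds below may be only part of what the source reports. "The series", "measured", "known", "first", "only" and "open" are said of these compounds alone.

Compound 1 `S=c1oc(-c2ccc3c(c2)OCCO3)nn1CNc1cccc(Cl)c1`: 6220 nM
Compound 2 `S=c1oc(-c2ccc3c(c2)OCCO3)nn1CNc1ccc(Br)cc1`: 14700 nM

In a functional assay, with a stated time of 6 min (a higher number here means a weaker inhibitor, a lower number a stronger inhibitor), compound 2 stands highest of the two numbers; its nearest neighbour is compound 1, and the step of a 2.4-fold higher number from compound 1 to compound 2 (0.37 log units; beyond the scatter) is modest. Compound 3 `O=[N+]([O-])c1cccc(NCn2nc(-c3ccc4c(c3)OCCO4)oc2=S)c1` differs from compound 2 by 3-nitrophenyl in place of 4-bromophenyl on an amine nitrogen. Going by the values given here, only that one measured step concerns a change of the aryl group on the amine nitrogen, and it was modest, so a modest step in this assay is expected, with the direction open. Compound 3 is therefore expected to give 9000 nM, within 3500 nM to 25000 nM. The step expected is a 1.6-fold lower number from compound 2 to compound 3 (0.21 log units; within the scatter).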

Compound 3, half-maximal inhibitory concentration: 8870 nM
Compound 3: middle estimate off by 1.0-fold (0.01 log units), on the high side; low and high end bracket the measured number.
By their numbers in this assay, from the lowest: compounds 1, 3 and 2 (each within the scatter of the next, the first and the last beyond it).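

In this assay, a 1.4-fold higher number from compound 1 to compound 3 (0.15 log units; within the scatter) and a 1.7-fold lower number from compound 2 to compound 3 (0.22 log units; within the scatter) both lie within the scatter, so compound 3 cannot be told apart from either neighbour. A nitro group on the phenyl ring therefore keeps the number in the same range as the halogens, and only the gap between compound 1 and compound 2 stays beyond the scatter. Nothing measured here explains these close numbers. Compound 2 and compound 3 differ in both the group and its ring position, and the compounds shown do not separate these two changes. A 4-nitrophenyl or a 3-aminophenyl group on the amine nitrogen remains an open case.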